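The compounds below may be only part of what the source reports. "The series", "measured", "known", "first", "only" and "open" are said of these compounds alone.

Measured compounds:
compound 1, `CCc1nc(NC(CC)CC)c(OC)nc1-c1ccc(OC)cc1C(F)(F)F`, 2 h
compound 2, `CCc1nc(-c2ccc(OC)cc2C(F)(F)F)c(CC)nc1NC(CC)CC`, 0.0717 h
compound 3, `CCc1nc(NC(CC)CC)c(OC)nc1-c1ccc(OC(F)F)cc1Cl`, 0.783 h

The read-out throughout is an in vitro ADME assay on microsomes (Rattus norvegicus) for metabolic stability; a lower number here means that the compound disappears faster, a higher number that the compound lasts longer. Compound 2 stands lowest of the three numbers; compound 3 is nearest to it and compound 1 furthest, both gaps beyond the scatter. Among the measured compounds shown here, the one measured single-point step, a 28-fold lower number from compound 1 to compound 2 (1.45 log units; beyond the scatter), is large.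

Compound 4, `CCc1nc(-c2ccc(OC)cc2O)c(CC)nc1NC(CC)CC`, is the unmeasured member. It differs from compound 2 in one place: hydroxy in place of trifluoromethyl on an aromatic carbon. For the measured compounds named here, no measured pair shows hydroxy in place of trifluoromethyl, nor any change at that place, so no step bears directly on it. The step from compound 1 to compound 2 changes a different group and shows only that a single replacement on the shared core can move this assay by a large amount. The direction of the present change is not constrained by the data.

The expectation for compound 4 is therefore centred near the number of compound 2, with a wide range. The expected step is a 1.4-fold higher number from compound 2 to compound 4 (0.14 log units; within the scatter), which may well fall within the scatter. Compound 4 is estimated at 0.1 h in this assay, with a range of 0.03 h to 0.5 h.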

Compound 4, half-life: 0.0983 h
Estimate against measurement, compound 4: 1.0-fold (0.01 log units) above, and the stated range covers the measured number.
By their numbers in this assay, from the lowest: compounds 2 and 4 (each within the scatter of the next); then compound 3; then compound 1.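

In this assay, the first change seen at this place, on an aromatic carbon ortho to a large group and meta to a methoxy group, reads a 1.4-fold higher number from compound 2 to compound 4 (0.14 log units; within the scatter). Trifluoromethyl, with 4 heavy atoms and no hydrogen-bond donor or acceptor, leaves here, and hydroxy, with 1 heavy atom, 1 hydrogen-bond donor and 1 hydrogen-bond acceptor, enters, yet the two numbers stay within the scatter of each other on this background; the only other single-place step, a 28-fold lower number from compound 1 to compound 2 (1.45 log units; beyond the scatter), is large and lies at a different place. Nothing measured in the series bears on why this exchange leaves the read-out unresolved.

From the compounds shown here alone, whether hydroxy in place of trifluoromethyl reads the same on the core of compound 1, which carries methoxy where compound 2 carries ethyl, remains open, since the single result here comes from the ethyl background alone. Also open, going by these compounds, is how this assay responds to other groups at this place, such as an amine, a carboxylic acid or a longer chain.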